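Three Compounds with Level Numbers and a Fourth to Come

The compounds below may be only part of what the source reports. "The series", "measured", "known", "first", "only" and "open" are said of these compounds alone.

In an assay on CHO cells for displacement of a labelled ligand from adenosine receptor A1 (Homo sapiens), read by scintillation counting, with a stated time of 120 min, tested at 10 uM (a lower number here means less inhibition, a higher number more inhibition at the concentration tested (going by the name of the read-out)), the three measured compounds stand as follows:
Compound 1, `Nc1scc(CN2CCN(c3ccc(F)cc3Cl)CC2)c1C(=O)c1ccc(Cl)cc1`, gives 0%.
Compound 2, `Nc1scc(CN2CCN(c3cccc(C(F)(F)F)c3)CC2)c1C(=O)c1ccc(Cl)cc1`, gives 0%.
Compound 3, `Nc1scc(CN2CCN(c3cccc4ccccc34)CC2)c1C(=O)c1ccc(Cl)cc1`, gives 1%.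

Compound 3 holds the highest of the three numbers, yet the gaps are within the scatter: a number 1 percentage points higher from compound 1 to compound 3 (within the scatter), and a number 1 percentage points higher from compound 2 to compound 3 (within the scatter). Going by the values given here, no compound stands apart. Compound 4, `Nc1scc(CN2CCN(c3cc(F)ccc3F)CC2)c1C(=O)c1ccc(Cl)cc1`, continues from compound 3 with one change: 2,5-difluorophenyl in place of naphthalen-1-yl on an amine nitrogen in a ring. Among the compounds with values here, the steps that bear on this are the earlier exchanges of the group on the ring nitrogen, both within the scatter, as is no change at the digits printed from compound 1 to compound 2 (within the scatter). The expected step is therefore a number 1 percentage points lower from compound 3 to compound 4 (within the scatter), none beyond the scatter. Compound 4 is estimated to give 0%, with a range from -6% to 8%.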

Compound 4, a percentage reported as inhibition, at one concentration (the size of the read-out at that concentration, not a potency): 1%
The estimate for compound 4 lay 1 percentage points below the measured number; the range from low to high includes it.
By their numbers in this assay, from the lowest: compounds 1, 2, 3 and 4 (each within the scatter of the next).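

In this assay, the 2,5-difluorophenyl group gives no change at the digits printed from compound 3 to compound 4 (within the scatter), a number 1 percentage points higher from compound 2 to compound 4 (within the scatter) and a number 1 percentage points higher from compound 1 to compound 4 (within the scatter). On this amine nitrogen in a ring, a single aromatic ring carrying two fluorines therefore reads the same as the larger naphthalen-1-yl, which has two aromatic rings, and the same as the two other substituted phenyl groups. Nothing available explains this flat reading.

Going by these compounds, it remains open whether a benzyl group, a pyridine ring or a carboxylic acid on this nitrogen would move the number beyond the scatter. On these data alone, all four compounds share one core, so the effect of a change there also remains open.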